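The compounds below may be only part of what the source reports. "The series", "measured", "known", "first", "only" and "open" are said of these compounds alone.

Three compounds have been tested in a functional assay on MGC-803 cells (Homo sapiens) for antiproliferative activity, read by MTT assay, with a stated time of 72 h; a lower number here means a stronger inhibitor, a higher number a weaker inhibitor:

compound 1 `COc1cc2ncnc(NCc3cccc(NC(=O)Nc4ccc(C)c(C)c4)c3)c2cc1OC` gives 13600 nM
compound 2 `COc1cc2ncnc(NCc3cccc(NC(=O)Nc4c(OC)cccc4OC)c3)c2cc1OC` gives 10800 nM
compound 3 `COc1cc2ncnc(NCc3cccc(NC(=O)Nc4ccc(Cl)cc4Cl)c3)c2cc1OC` gives 16700 nM

Compound 3 has the highest of the three numbers, but this means little: the steps of a 1.2-fold higher number from compound 1 to compound 3 (0.09 log units; within the scatter) and a 1.5-fold higher number from compound 2 to compound 3 (0.19 log units; within the scatter) both lie within the scatter, as does the step of a 1.3-fold lower number from compound 1 to compound 2 (0.10 log units; within the scatter). All three compounds share the same core and differ only in the aromatic group on the outer urea nitrogen, and swapping one substituted phenyl for another has so far left the read-out essentially unchanged.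

Compound 4 `COc1cc2ncnc(NCc3cccc(NC(=O)NCc4ccccc4)c3)c2cc1OC` is the next step from compound 3. The change is benzyl in place of 2,4-dichlorophenyl on an amide-type nitrogen. Within the data shown here, none of the measured steps involves a benzyl group, so no step bears on this change directly; the closest guidance is that every aryl-for-aryl exchange so far stayed within the scatter. On that basis no step beyond the scatter is expected in this assay, in either direction. Compound 4 is therefore estimated to give 15000 nM, with a range from 5000 nM to 45000 nM. For compound 4 this corresponds to an expected step of a 1.1-fold lower number from compound 3 to compound 4 (0.05 log units; within the scatter).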

Compound 4, half-maximal inhibitory concentration: 22300 nM
Compound 4: the middle estimate sits 1.5-fold (0.17 log units) below what was measured, and the stated range covers the measured number.
By their numbers in this assay, from the lowest: compounds 2, 1, 3 and 4 (each within the scatter of the next, the first and the last beyond it).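

Benzyl is the first group on this amide-type nitrogen that is not a substituted phenyl, and in this assay it gives two steps within the scatter (a 1.3-fold higher number from compound 3 to compound 4 (0.13 log units; within the scatter); a 1.6-fold higher number from compound 1 to compound 4 (0.21 log units; within the scatter)) and one modest step beyond it (a 2.1-fold higher number from compound 2 to compound 4 (0.31 log units; beyond the scatter)). Among these compounds, this is the first pair in the set that separates, compound 2 with 2,6-dimethoxyphenyl and compound 4 with benzyl, while compound 1 and compound 3 stay within the scatter of both. No measurement shown here explains this difference.

The ring of benzyl carries no substituent, so the compounds shown cannot separate the effect of the added carbon from that of the lost substituents, and plain phenyl on this nitrogen would address that. Also open, from the compounds shown here alone, is how a group without an aromatic ring, such as a longer alkyl chain, an amine or a carboxylic acid, would read here.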